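Permeability of an indole diacid bearing a fluoromethylphenyl tail

A few compounds are considered here, and "the series" means these few. Any claim that something is new, unique, unknown or untested is made for them only; others in the source may bear on it.

Compound 1 `Cc1c(CCCC(=O)O)c2cccc(/C=C/c3ccc(OCCCCc4ccccc4)cc3)c2n1CC(=O)O` was examined in a physicochemical assay for permeability, using PAMPA, with a stated time of 4 h, at pH 7.4, tested at 50 uM; on this read-out higher numbers stand for higher permeability and lower numbers for lower permeability. In this assay compound 1 gives only a limit, < 0.05 10^-6 cm/s, so its true value is not known. Two related compounds carry an alkyne in place of the alkene of compound 1: compound 2 `Cc1c(Cl)cccc1CCCCOc1ccc(C#Cc2cccc3c(CCCC(=O)O)c(C)n(CC(=O)O)c23)cc1` gives 3.2 10^-6 cm/s in this assay, and compound 3 `Cc1c(F)cccc1CCCCOc1ccc(C#Cc2cccc3c(CCCC(=O)O)c(C)n(CCCC(=O)O)c23)cc1`, which also carries a longer acid chain on the core nitrogen, gives 12.4 10^-6 cm/s. Compound 4 `Cc1c(F)cccc1CCCCOc1ccc(/C=C/c2cccc3c(CCCC(=O)O)c(C)n(CC(=O)O)c23)cc1` has not been measured in this assay. It differs from compound 1 by 3-fluoro-2-methylphenyl in place of phenyl on a saturated chain carbon, four bonds along the chain from an oxygen on an aromatic ring. Within the data shown here, no step between measured compounds matches this change, so the effect must be estimated. Since compound 2 carries a chloro-methylphenyl tail on an otherwise similar frame and gives 3.2 10^-6 cm/s, compound 4 is expected to sit higher than compound 1, with a step of an at least 12-fold higher number from compound 1 to compound 4 (1.07 log units; beyond the scatter). Compound 4 is therefore estimated at 0.6 10^-6 cm/s, between 0.05 10^-6 cm/s and 4 10^-6 cm/s.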

Compound 4, apparent permeability: 1.5 10^-6 cm/s
Estimate against measurement, compound 4: 2.5-fold (0.40 log units) below, within the range that was stated.
By their numbers in this assay, from the lowest: compound 4; then compound 2; then compound 3. At a limit, below all of these: compound 1.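

In this assay, the change from phenyl to 3-fluoro-2-methylphenyl, on a saturated chain carbon, four bonds along the chain from an oxygen on an aromatic ring, can now be read on its own: an at least 30-fold higher number from compound 1 to compound 4 (1.47 log units; beyond the scatter). Unlike compound 2 and compound 3, which also carry an alkyne, compound 4 keeps the alkene of compound 1, so the tail is the one difference in this step. The true size of the step remains unknown, as the reading of compound 1 is a limit and not a number: the limit of < 0.05 10^-6 cm/s in this assay, at which 1 of the 4 values shown sits.

The compounds shown leave open which part of the new tail goes with the step, as no phenyl tail with the fluorine alone or the methyl alone stands among them. Also open, going by these compounds, is how a chloro group in place of the fluorine, or a longer acid chain on the core nitrogen, would read with the alkene kept.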